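This account rests on a few compounds, and the source may have more. Where it says the series, first, only, none or still open, it means among the compounds named here.

Measured compounds:
- compound 1, `O=C(CN(c1ncnc2c1ncn2C1CCCCO1)C1CC1)N[C@@H](CCC(=O)OCc1ccccc1)C(=O)OCc1ccccc1`, giving 25.2%
- compound 2, `N=C(N)NCCC[C@H](NC(=O)CN(c1nc(Cl)nc2[nH]cnc12)C1CC1)C(=O)OCc1ccccc1`, giving 30.4%
- compound 3, `NCCCC[C@H](NC(=O)CN(c1nc(Cl)nc2[nH]cnc12)C1CC1)C(=O)O`, giving 28.8%

All three numbers come from a functional assay on the whole organism (Tail, strain ICR) with Mus musculus as the target, in the tail flick test, with a stated time of 90 min, at a dose of 25 umol/kg by the oral route; on this read-out higher numbers stand for a stronger effect at the one dose given and lower numbers for a weaker effect. Compound 1 has the smallest of the three numbers, but its gaps to compound 3 and to compound 2 both lie within the usual scatter of this assay, so the three compounds cannot be told apart on these data.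

Compound 4, `CSCC[C@H](NC(=O)CN(c1ncnc2c1ncn2C1CCCCO1)C1CC1)C(=O)OCc1ccccc1`, has not yet been measured. It differs from compound 1 in one place: methylsulfanyl in place of benzyloxycarbonyl on a saturated chain carbon, three bonds along the chain from an amide-type nitrogen and a carbonyl carbon. Going by the values given here, no step between two measured compounds describes this kind of change, so there is no measured precedent to lean on. The three measured compounds carry quite different groups at the same place on the chain and still give numbers within the scatter of one another, which suggests that this assay is not very sensitive to what sits there. The step from compound 1 to compound 4 is therefore expected to be small, a number 2.8 percentage points higher from compound 1 to compound 4 (within the scatter), with no clear direction beyond the scatter. Compound 4 is estimated at 28%, within a range from 15% to 45%.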

Compound 4, a percentage reported as activity, at one dose (the size of the read-out at that dose, not a potency): 42.7%
Estimate against measurement, compound 4: 14.7 percentage points below; low and high end bracket the measured number.
By their numbers in this assay, from the lowest: compounds 1, 3 and 2 (each within the scatter of the next); then compound 4.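

In this assay, swapping the benzyloxycarbonyl group for a methylsulfanyl group gives a number 17.5 percentage points higher from compound 1 to compound 4 (beyond the scatter). This is the only step shown that changes one place alone, and it shows that the group at this position can move the read-out beyond the scatter. The entering group has 2 heavy atoms and no ring, against 10 heavy atoms and an aromatic ring in the group that leaves, so a much smaller group here does not lower the number. No measurement shown explains the rise. Still open, on these data alone, is whether the sulfur matters or only the loss of the benzyloxycarbonyl group. A methoxy group or a carboxylic acid at this place, on the same core, would help separate the two.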